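Swapping the Amine at the End of the Side Chain

The source may hold more compounds than are shown below. What is called first, only, known or untested is meant among the compounds shown, and "the series" means these compounds.

Three measured compounds share one core and differ at its edges. In a functional assay on HT-29 cells (Homo sapiens) for inhibition, read by MTT assay, with a stated time of 72 h (on this read-out lower numbers stand for stronger inhibition and higher numbers for weaker inhibition), compound 1 `COc1cc2c(Oc3ccc(NC(=O)c4nn(-c5ccccc5C)c(=O)cc4C)cc3F)ccnc2cc1OCCCN1CCN(C)CC1` gives 3790 nM. Going by the values given here, compound 2 `COc1cc2c(Oc3ccc(NC(=O)c4nn(-c5ccccc5OC(F)(F)F)c(=O)cc4C)cc3F)ccnc2cc1OCCCN1CCN(C)CC1` gives 180 nM in this assay; the one change between them brought a 21-fold lower number from compound 1 to compound 2 (1.32 log units; beyond the scatter). Compound 3 `COc1cc2c(Oc3ccc(NC(=O)c4nn(-c5cccc(F)c5)c(=O)cc4C)cc3F)ccnc2cc1OCCCN1CCCC1` gives 250 nM, the second highest of the three numbers, within the scatter of compound 2 and well below compound 1. Compound 4 `COc1cc2c(Oc3ccc(NC(=O)c4nn(-c5cccc(F)c5)c(=O)cc4C)cc3F)ccnc2cc1OCCCN1CCN(C)CC1` is not yet measured and differs from compound 3 only by 4-methylpiperazin-1-yl in place of pyrrolidin-1-yl on a saturated chain carbon, three bonds along the chain from an oxygen on an aromatic ring. Among the compounds with values here, no measured step concerns this part of the molecule; the single step seen, from compound 1 to compound 2, lies elsewhere. The step of no change at the digits printed from compound 3 to compound 4 (within the scatter) is therefore expected to stay within the scatter. Compound 4 is thus estimated at 250 nM, with a range from 100 nM to 650 nM.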

Compound 4, half-maximal inhibitory concentration: 250 nM
Estimate against measurement, compound 4: no gap at the digits printed; low and high end bracket the measured number.
By their numbers in this assay, from the lowest: compounds 2, 3 and 4 (each within the scatter of the next); then compound 1.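

In this assay, going by these compounds alone, 4-methylpiperazin-1-yl in place of pyrrolidin-1-yl gives no change at the digits printed from compound 3 to compound 4 (within the scatter) and so shows, for the first time, that this end of the side chain tolerates the swap with 3-fluorophenyl on the aromatic nitrogen. With 4-methylpiperazin-1-yl kept, 3-fluorophenyl in place of 2-(trifluoromethoxy)phenyl gives a 1.4-fold higher number from compound 2 to compound 4 (0.14 log units; within the scatter) while 3-fluorophenyl in place of 2-methylphenyl gives a 15-fold lower number from compound 1 to compound 4 (1.18 log units; beyond the scatter). No available evidence explains these results. Going by these compounds, whether morpholin-4-yl or a dimethylamino group at the chain end would give a similar number remains open.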